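The source may hold more compounds than are shown below. What is called first, only, known or untested is meant among the compounds shown, and "the series" means these compounds.

Series notes. Compound 1 `O=C(/C=C\c1cccc(O)c1)N1N=C(c2ccncc2)OC1c1c[nH]c2ccccc12`, compound 2 `O=C(/C=C\c1ccccc1[N+](=O)[O-])N1N=C(c2ccncc2)OC1c1c[nH]c2ccccc12` and compound 3 `O=C(/C=C\c1ccccc1F)N1N=C(c2ccncc2)OC1c1c[nH]c2ccccc12` share one core and differ only in the aryl group on the double-bonded chain carbon bound to a double-bonded chain carbon. In an ADME assay on HeLa cells (Homo sapiens) for cytotoxicity, read by MTT assay, with a stated time of 72 h (a lower number here means a stronger inhibitor of growth, a higher number a weaker inhibitor of growth), compound 1 gives only a limit, > 30 ug/mL. Compound 2 likewise reaches only the limit, > 30 ug/mL, in this assay. Compound 3 also shows only the limit, > 30 ug/mL, in this assay. With every value a limit, nothing can be read from the steps: a step that the two limits leave unreadable from compound 1 to compound 2, a step that the two limits leave unreadable from compound 1 to compound 3 and a step that the two limits leave unreadable from compound 2 to compound 3 are all unreadable, and the limit of > 30 ug/mL in this assay, at which 3 of the 3 values shown sit, marks the point at which all three values sit. Compound 4 `O=C(/C=C\c1cccc(Cl)c1Cl)N1N=C(c2ccncc2)OC1c1c[nH]c2ccccc12` is the next member, differing from compound 3 by 2,3-dichlorophenyl in place of 2-fluorophenyl on a double-bonded chain carbon bound to a double-bonded chain carbon. Across compounds 1 to 3 no change of ring substituent moved a value off the limit. For the change to compound 4 no size or direction can be read from these measured steps. The step that the limit leaves unreadable from compound 3 to compound 4 is estimated only to leave compound 4 near the limit. The expected value for compound 4 in this assay is 40 ug/mL, within 15 ug/mL to 150 ug/mL, with a bare limit the most likely report.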

Compound 4, concentration for 50% growth inhibition: > 30 ug/mL
Compound 4: a limit, no number (the forecaster's own chance of this, stated with the estimate: 75%); the middle value is on the limit's open side.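

Compound 4 also gives only a limit in this assay, so the steps to it from compound 1, compound 2 and compound 3 cannot be read. All values in the series now sit at one limit: the limit of > 30 ug/mL in this assay, at which 4 of the 4 values shown sit.

The compounds shown leave open whether any aryl group on the shared core moves a value off this limit.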